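Swapping thiophen-3-yl for iodo on a weak compound

A few compounds are considered here, and "the series" means these few. Any claim that something is new, unique, unknown or untested is made for them only; others in the source may bear on it.

In a functional assay on HepG2 cells (Homo sapiens) for antiproliferative activity, read by XTT assay, with a stated time of 72 h (a higher number here means a weaker inhibitor, a lower number a stronger inhibitor), compound 2 `CNc1ncnc2c1c(-c1ccsc1)cn2[C@@H]1O[C@H](CO)[C@@H](O)[C@H]1O` gives > 20000 nM which is a limit. Compound 1 `CSc1ncnc2c1c(-c1ccsc1)cn2[C@@H]1O[C@H](CO)[C@@H](O)[C@H]1O` gives > 15000 nM which is also a limit. From the compounds shown here alone, compound 3 `Cc1ncnc2c1c(-c1ccsc1)cn2[C@@H]1O[C@H](CO)[C@@H](O)[C@H]1O` gives 4720 nM and so shows an at least 3.1-fold lower number from compound 1 to compound 3 (0.50 log units; beyond the scatter) and an at least 4.2-fold lower number from compound 2 to compound 3 (0.62 log units; beyond the scatter) while a step that the two limits leave unreadable from compound 1 to compound 2 stays open. Among the compounds with values here, compound 4 `CNc1ncnc2c1c(I)cn2[C@@H]1O[C@H](CO)[C@@H](O)[C@H]1O` carries iodo in place of thiophen-3-yl on an aromatic carbon and none of the measured steps touches that place. They bear on it only loosely, so a lower number in this assay is expected with little confidence. The expected change is an at least 3.3-fold lower number from compound 2 to compound 4 (0.52 log units; beyond the scatter) and it remains a rough estimate. For compound 4 the estimated value is 6000 nM with an expected range from 500 nM to 30000 nM in this estimate.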

Compound 4, half-maximal inhibitory concentration: > 20000 nM
Compound 4 gave a limit, no number; the forecaster's own chance of this, stated with the estimate: 35%; middle value at least 3.3-fold (0.52 log units) away from the limit.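

In this assay compound 4 gives > 20000 nM, which is a limit. Within the data shown here, compound 2 gives > 20000 nM, also a limit, so no step between the two can be read. The compounds shown leave open how iodo and thiophen-3-yl compare.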